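From cyano to (4-methylpiperazin-1-yl)sulfonyl in compound 4

The compounds below may be only part of what the source reports. "The series", "measured", "known", "first", "only" and "open" are said of these compounds alone.

Measured in a functional assay on L1210 cells (Mus musculus) for inhibition; on this read-out lower numbers stand for stronger inhibition and higher numbers for weaker inhibition:
- compound 1 `C#CCN(Cc1ccc2nc(C)nc(O)c2c1)c1cccc(CC)c1`: 5000 nM
- compound 2 `C#CCN(Cc1ccc2nc(C)nc(O)c2c1)c1cccc(C#C)c1`: > 2400 nM, a limit
- compound 3 `C#CCN(Cc1ccc2nc(C)nc(O)c2c1)c1ccc(C#N)cc1`: > 5000 nM, a limit

On the numbers shown, compound 3 has no readable value: compound 3 stands at > 5000 nM, which is a limit. Compound 4 `C#CCN(Cc1ccc2nc(C)nc(O)c2c1)c1ccc(S(=O)(=O)N2CCN(C)CC2)cc1` has (4-methylpiperazin-1-yl)sulfonyl in place of cyano on an aromatic carbon, ((4-methylpiperazin-1-yl)sulfonyl in place of cyano on an aromatic carbon).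

Among the measured compounds shown here, two measured steps bear on this by changing the same aromatic substituent: a number no lower from compound 1 to compound 3 (the limit leaves the size open), and a step that the two limits leave unreadable from compound 2 to compound 3. For the measured compounds named here, neither gives a size, and no measured step replaces cyano with a sulfonyl group. Going by the values given here, the only readable number is that of compound 1, at 5000 nM, so a clear step in this assay in either direction is not expected, and the reading is expected to stay weak. The step estimated here is a step that the limit leaves unreadable from compound 3 to compound 4, and it is expected to be poorly defined. For compound 4 the expected value is 6000 nM, with an estimated range from 1500 nM to 25000 nM.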

Compound 4, half-maximal inhibitory concentration: > 10000 nM
Compound 4: a limit, no number (the forecaster's own chance of this, stated with the estimate: 55%); at least 1.6-fold (0.22 log units) between middle value and limit.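

Compound 3 and compound 4 both carry limits rather than numbers, and the step between them cannot be read. The compounds shown leave open how strongly either one inhibits in this assay, and whether (4-methylpiperazin-1-yl)sulfonyl in place of cyano changes the reading at all.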